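Hydrazone-linked quinoxaline series: a thiophene swap on the aldimine carbon

The source may hold more compounds than are shown below. What is called first, only, known or untested is meant among the compounds shown, and "the series" means these compounds.

Measured compounds:
compound 1 `COc1cc(/C(C)=N/Nc2nc3ccccc3nc2Cc2ccccc2)cc(OC)c1OC` gives 260000 nM
compound 2 `COc1ccc(/C(C)=N/Nc2nc3ccccc3nc2Cc2ccccc2)cc1` gives 280000 nM
compound 3 `Clc1ccccc1/C=N/Nc1nc2ccccc2nc1Cc1ccccc1` gives 87000 nM

All three values come from an assay on isolated protein for inhibition of Amine oxidase [flavin-containing] B (Homo sapiens), read by spectrophotometry; a higher number here means a weaker inhibitor, a lower number a stronger inhibitor. Compound 3 has the lowest number of the three; compound 1 and compound 2 both sit above it by margins beyond the usual scatter, so compound 3 is the strongest inhibitor measured so far, though still a weak one in absolute terms. Compound 1 and compound 2 lie within the scatter of each other, so nothing separates them.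

The next compound, compound 4 `Cc1ccsc1/C=N/Nc1nc2ccccc2nc1Cc1ccccc1`, is compound 3 with a single change: 3-methylthiophen-2-yl in place of 2-chlorophenyl on a carbon with a double bond to nitrogen. The shared core is unchanged; only the group on the carbon with a double bond to nitrogen is exchanged.

Among the measured compounds shown here, no step between two measured compounds alters this position, so there is no precedent for what a 3-methylthiophen-2-yl in place of 2-chlorophenyl does. Compound 1 and compound 2 show that other aryl groups at this carbon give weaker inhibition than compound 3, so the expectation for compound 4 is a modest weakening, possibly none beyond the scatter. The step of a 1.5-fold higher number from compound 3 to compound 4 (0.17 log units; within the scatter) is the estimated size of that shift. Compound 4 is expected to give about 130000 nM, within a range of 45000 nM to 380000 nM in this assay.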

Compound 4, half-maximal inhibitory concentration: 860000 nM
For compound 4 the middle estimate is 6.6-fold (0.82 log units) below the measured one; the measured number lies above the stated range.
By their numbers in this assay, from the lowest: compound 3; then compounds 1 and 2 (each within the scatter of the next); then compound 4.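

Among the compounds shown here, the exchange of 2-chlorophenyl for 3-methylthiophen-2-yl gives a 9.9-fold higher number from compound 3 to compound 4 (0.99 log units; beyond the scatter) in this assay and is the first step that can be read at this carbon with a double bond to nitrogen. It shows that the group on this carbon is not freely interchangeable in this series, since a single exchange there moves the number well beyond the scatter. The step changes the ring and its substituent together, and no data available here explain the loss.

The compounds shown do not separate these two parts of the change: thiophen-2-yl without the methyl and 2-methylphenyl would each alter only one of them relative to compound 3 or compound 4. Also open, going by these compounds, is how this carbon responds to other kinds of group, such as an aryl ring carrying an amine or a carboxylic acid, and whether a methyl on the carbon itself matters, since compound 1 and compound 2 differ from compound 3 in more than one place.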